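The source may report more compounds than this note shows. Statements on the series, on what has been measured and on what is new or still open speak of the compounds shown alone.

Measured so far:
compound 1 `CC(C)(C)OC(=O)N1CCN(C(=S)SCc2cn(-c3ccccc3F)nn2)CC1` gives 89600 nM
compound 2 `Cc1cc(=O)oc2cc(OCCn3cc(CSC(=S)N4CCN(C(=O)OC(C)(C)C)CC4)nn3)ccc12` gives 90400 nM

In a functional assay on MCF7 cells (Homo sapiens) for inhibition, read by MTT assay, with a stated time of 72 h (on this read-out higher numbers stand for weaker inhibition and lower numbers for stronger inhibition), compound 1 gives 89600 nM, and in this assay compound 2 gives 90400 nM. The two numbers lie within the usual scatter of each other, so nothing separates them. Among the compounds with values here, no pair that differs in one place has been measured, so no step size can be taken from the data. Compound 3 `COc1ccc(-n2cc(CSC(=S)N3CCN(C(=O)OC(C)(C)C)CC3)nn2)cc1` differs from compound 1 as follows: 4-methoxyphenyl in place of 2-fluorophenyl on an aromatic nitrogen. The expected step of a 1.1-fold lower number from compound 1 to compound 3 (0.02 log units; within the scatter) is none beyond the scatter. Compound 3 is expected to give 85000 nM, between 40000 nM and 180000 nM.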

Compound 3, half-maximal inhibitory concentration: 93100 nM
Estimate against measurement, compound 3: 1.1-fold (0.04 log units) below, and the stated range covers the measured number.
By their numbers in this assay, from the lowest: compounds 1, 2 and 3 (each within the scatter of the next).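

In this assay, the group on the aromatic nitrogen now has its first one-place comparison: with 4-methoxyphenyl in place of 2-fluorophenyl, the step is (a 1.0-fold higher number from compound 1 to compound 3 (0.02 log units; within the scatter)). This exchange of a fluorine for a methoxy group, with one hydrogen-bond acceptor entering by the count, does not separate the two compounds. No measurement on hand offers an explanation for this result. Going by these compounds, whether an amine or a carboxylic acid on the phenyl ring would separate from compound 1 stays open. A benzyl group on the aromatic nitrogen also remains an open case.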